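Bromo Substitution on Two Related Cores and Liver Stability

The compounds below may be only part of what the source reports. "The series", "measured", "known", "first", "only" and "open" are said of these compounds alone.

Of the compounds shown here, three have been measured in an ADME assay on microsomes from liver (Homo sapiens) for metabolic stability; on this read-out lower numbers stand for a shorter-lived compound and higher numbers for a longer-lived compound. Compound 1 `CCCNC(=O)C1CCN(C(=O)c2cc3ncsc3n2Cc2ccc(OC)cc2)CC1` gives 0.543 h in this assay, the highest of the three numbers. Compound 2 `CCCNC(=O)C1CCN(C(=O)c2cc3occc3n2Cc2ccc(OC)cc2)CC1` gives 0.0457 h in this assay, and compound 3 `CCCNC(=O)C1CCN(C(=O)c2cc3oc(Br)cc3n2Cc2ccc(OC)cc2)CC1` gives 0.158 h in this assay. Compound 1 and compound 2 share most of their make-up but differ in their cores; the difference between the two cores is not broken down here.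

Compound 3 arises from compound 2 by one change, (bromo in place of hydrogen on an aromatic carbon), and this change gave a 3.5-fold higher number from compound 2 to compound 3 (0.54 log units; beyond the scatter) in this assay.

Compound 4 `CCCNC(=O)C1CCN(C(=O)c2cc3nc(Br)sc3n2Cc2ccc(OC)cc2)CC1` is not yet measured. It arises from compound 1 by the same kind of change, (bromo in place of hydrogen on an aromatic carbon). The surroundings of the place are not the same: in compound 3 the bromo sits on a five-membered aromatic ring with one oxygen, next to the ring oxygen, whereas in compound 4 it sits on a five-membered aromatic ring with one nitrogen and one sulfur, next to the ring nitrogen and next to the ring sulfur.

Among the compounds with values here, on the single earlier example, a rise is expected for compound 4, though a smaller one is estimated than a 3.5-fold higher number from compound 2 to compound 3 (0.54 log units; beyond the scatter), because a 3.5-fold higher number from compound 2 to compound 3 (0.54 log units; beyond the scatter) is the only step that supports it and it stands on a different core: the expected step is a 2.0-fold higher number from compound 1 to compound 4 (0.31 log units; beyond the scatter) in this assay. Compound 4 is therefore estimated at 1.1 h in this assay, expected to fall between 0.45 h and 3 h.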

Compound 4, half-life: 0.368 h
Compound 4: middle estimate off by 3.0-fold (0.48 log units), on the high side, outside the stated range (below it).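

On the core of compound 1, bromo in place of hydrogen on an aromatic carbon gives a 1.5-fold lower number from compound 1 to compound 4 (0.17 log units; within the scatter) in this assay, so on this core the change leaves a difference that cannot be told apart from the ordinary spread of repeated measurements. Set beside the earlier step, this shows that the effect of the change did not carry over unchanged from one core to the other: the same change on two cores in this assay, a 3.5-fold higher number (0.54 log units; beyond the scatter) from compound 2 to compound 3 and a 1.5-fold lower number (0.17 log units; within the scatter) from compound 1 to compound 4, 5.1-fold (0.71 log units) apart, beyond the scatter of two such steps What this does not show is why the two cores part ways, whether the cores themselves or the different surroundings of the bromo are responsible, or what the same change would do on any further core, as each core offers only a single pair of compounds.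

The compounds shown leave open whether other small groups at the same place, such as chloro or methyl, would follow the pattern of the bromo on each core. They also leave open whether the two cores would still differ in this way if the propyl chain on the amide or the methoxy group on the benzyl ring were replaced, for example by a longer chain or by a fluoro group.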